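Para-substituent swap on the cinnamamide: isopropyl to iodo

The source may report more compounds than this note shows. Statements on the series, on what has been measured and on what is new or still open speak of the compounds shown alone.

Measured so far:
compound 1 `CCCc1cc(N)c2cc(NC(=O)/C=C/c3ccc(F)cc3)ccc2n1`, 130 nM
compound 2 `CCCc1cc(N)c2cc(NC(=O)/C=C/c3ccc(C(C)C)cc3)ccc2n1`, 2.9 nM
compound 3 `CCCc1cc(N)c2cc(NC(=O)c3ccc(-c4ccc(Cl)cc4)cc3)ccc2n1`, 0.7 nM

In an assay on isolated protein for displacement of a labelled ligand from melanin-concentrating hormone receptor 1 (Homo sapiens) (a lower number here means a stronger inhibitor, a higher number a weaker inhibitor), compound 2 stands second of the three numbers; compound 3 gives the lower number 0.7 nM and compound 1 the higher one 130 nM. Compound 4 `CCCc1cc(N)c2cc(NC(=O)/C=C/c3ccc(I)cc3)ccc2n1` differs from compound 2 by iodo in place of isopropyl on an aromatic carbon. Among the measured compounds shown here, the one step that bears on this position is a 45-fold lower number from compound 1 to compound 2 (1.65 log units; beyond the scatter), where a halogen at the same place gave the far higher number. Compound 4 puts a halogen back in place of isopropyl, so a move toward the number of compound 1 is expected, though iodo is not fluoro and the full reversal need not follow. The step from compound 2 to compound 4 is therefore expected to be a 3.1-fold higher number from compound 2 to compound 4 (0.49 log units; beyond the scatter). For compound 4 the estimate in this assay is 9 nM, with a range of 3 nM to 35 nM.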

Compound 4, half-maximal inhibitory concentration: 2.3 nM
The estimate for compound 4 lay 3.9-fold (0.59 log units) above the measured number, outside the stated range (below it).
By their numbers in this assay, from the lowest: compound 3; then compounds 4 and 2 (each within the scatter of the next); then compound 1.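

In this assay, iodo and isopropyl cannot be told apart on this aromatic carbon: a 1.3-fold lower number from compound 2 to compound 4 (0.10 log units; within the scatter), a change that leaves three carbons for one iodine. A halogen at this place therefore does not in itself bring the high number, and a 57-fold lower number from compound 1 to compound 4 (1.75 log units; beyond the scatter) shows how far two halogens can differ here. No measured evidence on the cause accompanies these numbers.

Open is whether fluoro stands alone among these groups, or whether bromo, or an amine, on the same carbon would also give a high number.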